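The source may report more compounds than this note shows. Statements on the series, on what has been measured and on what is new or still open speak of the compounds shown alone.

Measured compounds in an assay on isolated protein for binding affinity to 5-hydroxytryptamine receptor 1E (Homo sapiens); on this read-out lower numbers stand for stronger inhibition and higher numbers for weaker inhibition:
- compound 1 `Clc1ccc(-c2n[nH]cc2N2CCCNCC2)cc1`: compound 1 reaches only a limit of the assay, > 10000 nM
- compound 2 `Fc1ccc(-c2n[nH]cc2N2CCCNCC2)cc1`: compound 2 reaches only a limit of the assay, > 10000 nM
- compound 3 `COc1ccccc1-c1n[nH]cc1N1CCCNCC1`: compound 3 reaches only a limit of the assay, > 10000 nM

Compound 3 therefore stands on a limit of the assay, not on a number. The two further values shown are limits as well, so no ranking among compound 1, compound 2 and compound 3 can be read from this assay. Within the data shown here, the one step between measured compounds, a step that the two limits leave unreadable from compound 1 to compound 2, cannot be sized; the limit of > 10000 nM in this assay, at which 3 of the 3 values shown sit, covers every value shown.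

Compound 4 `c1ccc(-c2n[nH]cc2N2CCCNCC2)cc1` differs from compound 3 by hydrogen in place of methoxy on an aromatic carbon. Among the measured compounds shown here, no measured step touches a methoxy-to-hydrogen exchange, so nothing measured bears directly on it; the whole set only shows that none of the three aryl patterns so far reaches a readable number. The step that the limit leaves unreadable from compound 3 to compound 4 is expected to be none beyond the scatter. Compound 4 is accordingly expected at 20000 nM, within 5000 nM to 80000 nM, and most probably will again be reported only as a limit in this assay.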

Compound 4, inhibition constant: > 10000 nM
Compound 4 ended at the assay's limit (the forecaster's own chance of this, stated with the estimate: 80%); the middle value lies beyond the limit too.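

Among these compounds, no step from compound 1, compound 2 or compound 3 to compound 4 can be read, because each compound stands on a limit and not on a number: the limit of > 10000 nM in this assay, at which 4 of the 4 values shown sit. Still open, from the compounds shown here alone, is how hydrogen, fluoro, chloro and methoxy compare on the shared core, and whether any aromatic substituent there gives a readable number in this assay.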